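Trifluoromethyl for fluoro on the benzyl thioether

A few compounds are considered here, and "the series" means these few. Any claim that something is new, unique, unknown or untested is made for them only; others in the source may bear on it.

Three compounds of the series carry the same core and differ only in the benzyl group on the sulfur. Compound 1 `Cc1ccc(CSc2nc3nc(C)cc(Nc4cc(-c5ccccc5)[nH]n4)n3n2)cc1` gives 7310 nM in a functional assay on PC-9 cells (Homo sapiens) for inhibition, read by MTT assay, with a stated time of 72 h; a lower number here means a stronger inhibitor, a higher number a weaker inhibitor. Compound 2 `Cc1cc(Nc2cc(-c3ccccc3)[nH]n2)n2nc(SCc3cccc(Br)c3)nc2n1` gives 8900 nM, and compound 3 `Cc1cc(Nc2cc(-c3ccccc3)[nH]n2)n2nc(SCc3ccc(F)cc3)nc2n1` gives 8110 nM. Compound 3 holds the second highest of the three numbers; its nearest neighbour is compound 2 with a 1.1-fold lower number from compound 2 to compound 3 (0.04 log units; within the scatter), its furthest compound 1 with a 1.1-fold higher number from compound 1 to compound 3 (0.05 log units; within the scatter). The remaining pair shows a 1.2-fold higher number from compound 1 to compound 2 (0.09 log units; within the scatter). None of these steps leaves the scatter.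

Compound 4 `Cc1cc(Nc2cc(-c3ccccc3)[nH]n2)n2nc(SCc3ccc(C(F)(F)F)cc3)nc2n1` is not yet measured. It differs from compound 3 by trifluoromethyl in place of fluoro on an aromatic carbon. Within the data shown here, the steps that bear on this are the three above, all changes of the substituent on the benzyl ring, all within the scatter, so no step beyond the scatter is expected here in either direction. Compound 4 is therefore expected near 8500 nM, with a range of 4000 nM to 18000 nM. This corresponds to an estimated 1.0-fold higher number from compound 3 to compound 4 (0.02 log units; within the scatter).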

Compound 4, half-maximal inhibitory concentration: 4240 nM
Estimate against measurement, compound 4: 2.0-fold (0.30 log units) above, within the range that was stated.
By their numbers in this assay, from the lowest: compounds 4, 1, 3 and 2 (each within the scatter of the next, the first and the last beyond it).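

In this assay, trifluoromethyl in place of fluoro on the benzyl ring gives a 1.9-fold lower number from compound 3 to compound 4 (0.28 log units; within the scatter) and trifluoromethyl in place of methyl gives a 1.7-fold lower number from compound 1 to compound 4 (0.24 log units; within the scatter), so neither change at this position clears the scatter. Against the 3-bromophenyl group, 4-(trifluoromethyl)phenyl gives a 2.1-fold lower number from compound 2 to compound 4 (0.32 log units; beyond the scatter), the first step at this position to clear the scatter, though only modestly. No measurement at hand accounts for that step.

That step alters both the substituent and its place on the ring, and the compounds shown cannot separate the two. Also open is how an amine, a carboxylic acid or a longer chain on the benzyl ring would read, and whether any such group would move the number further than the groups shown here.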